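From compound 1 to compound 4: methoxy for methyl

A few compounds are considered here, and "the series" means these few. Any claim that something is new, unique, unknown or untested is made for them only; others in the source may bear on it.

In an ADME assay on Raji cells (Homo sapiens) for cytotoxicity, with a stated time of 72 h (a lower number here means that less compound is needed, a higher number that more compound is needed for the effect), compound 1 `Cc1cc(NC(=O)Nc2ccc(C)c(Cl)c2)c2ccccc2n1` gives > 25000 nM, which is a limit. Compound 2 `CCc1ccc(NC(=O)Nc2cc(C)nc3ccccc23)cc1` gives > 25000 nM, also a limit. Compound 3 `Cc1ccc(NC(=O)Nc2cc(C)nc3ccccc23)cc1` gives > 25000 nM, again a limit. The three compounds together stand as the limit of > 25000 nM in this assay, at which 3 of the 3 values shown sit.

Compound 4 `COc1ccc(NC(=O)Nc2cc(C)nc3ccccc23)cc1Cl` keeps the core of compound 1 and differs in one place: methoxy in place of methyl on an aromatic carbon. In words, this is methoxy in place of methyl on an aromatic carbon, ortho to a chloro group.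

Within the data shown here, two measured steps bear on this change: a step that the two limits leave unreadable from compound 1 to compound 3 and a step that the two limits leave unreadable from compound 2 to compound 3. Among the measured compounds shown here, neither has a readable size, and no measured step exchanges methyl for methoxy. The expectation therefore rests only on every measured compound sitting at a limit, and no shift beyond the scatter is expected in either direction in this assay.

The expected step is a step that the limit leaves unreadable from compound 1 to compound 4. For compound 4 the estimated value is 30000 nM, with an expected range from 15000 nM to 60000 nM. A report as a limit is the most likely expected outcome.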

Compound 4, half-maximal effective concentration: > 25000 nM
Compound 4 ended at the assay's limit; the forecaster's own chance of this, stated with the estimate: 85%; the middle value does not contradict the limit.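

No new step can be read: compound 1 and compound 4 both stand at a limit, so methoxy in place of methyl has no readable size. The compounds shown leave open whether any change in this series gives a readable effect in this assay, and all share one reading: the limit of > 25000 nM in this assay, at which 4 of the 4 values shown sit.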